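The source may hold more compounds than are shown below. What is called first, only, known or untested is meant among the compounds shown, and "the series" means these compounds.

Working notes on the series. Compound 1 `N#CC1(NC(=O)[C@@H](CC(=O)N2CCOCC2)CC2CCCCC2)CC1` gives 12 nM in an assay on isolated protein for inhibition of cathepsin S (Homo sapiens); a lower number here means tighter binding, a higher number weaker binding. For the measured compounds named here, compound 2 `N#C[C@@]1(NC(=O)[C@@H](CC(=O)N2CCOCC2)CC2CCCCC2)CCNC1` gives 123 nM in this assay, the highest of the two numbers so far; the change a 10-fold higher number from compound 1 to compound 2 (1.01 log units; beyond the scatter) is the only measured step and it does not concern the position varied next. Compound 3 `N#C[C@@]1(NC(=O)[C@@H](CC(=O)N2CCOCC2)CC2CCCCC2)CCN(C2CCCCC2)C1` differs from compound 2 by cyclohexyl in place of hydrogen on an amine nitrogen in a ring. Going by the values given here, no measured step bears on this change: nothing shows what substitution on that amine nitrogen in a ring does, and the step from compound 1 to compound 2 concerns a different part of the molecule. The expectation is therefore a step of a 1.5-fold lower number from compound 2 to compound 3 (0.19 log units; within the scatter) in this assay, with wide uncertainty in either direction. On that basis compound 3 is estimated at 80 nM in this assay, within a range of 20 nM to 320 nM.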

Compound 3, dissociation constant: 17.8 nM
Compound 3: middle estimate off by 4.5-fold (0.65 log units), on the high side; the whole stated range lies above it.
By their numbers in this assay, from the lowest: compounds 1 and 3 (each within the scatter of the next); then compound 2.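

In this assay, cyclohexyl in place of hydrogen on the amine nitrogen in a ring gives a 6.9-fold lower number from compound 2 to compound 3 (0.84 log units; beyond the scatter), the first measured result at this position. This nitrogen, two ring bonds from the ring atom that bears a cyano group, therefore accepts a large carbon-only ring with tighter binding, and it is a place where the number can be moved independently of the earlier change on the amide-type nitrogen. No measurement at hand accounts for the tighter binding.

Only hydrogen and cyclohexyl are shown on this nitrogen, so it remains open whether the step needs a six-membered carbon ring or would also follow from a smaller group such as methyl. A phenyl, a benzyl or an acetyl group on the same nitrogen would also remain to be compared with cyclohexyl.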